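This account rests on a few compounds, and the source may have more. Where it says the series, first, only, none or still open, it means among the compounds named here.

Of the compounds shown here, three of one shared core have been measured in an ADME assay on the whole organism (Rattus norvegicus) for pharmacokinetics, at a dose of 1 mg/kg by the oral route; on this read-out lower numbers stand for lower oral bioavailability and higher numbers for higher oral bioavailability. Compound 1 `CCC(CC)C1C(C(=O)c2ccc(OC)cc2)=C(O)C(=O)N1c1ccc(-c2ccon2)cc1` gives 18.9%, compound 2 `COc1ccc(C(=O)C2=C(O)C(=O)N(c3ccc(-c4ccon4)cc3)C2c2ccccc2OC)cc1` gives 19.9%, and compound 3 `COc1ccccc1C1C(C(=O)C(C)(C)C)=C(O)C(=O)N1c1ccc(-c2ccon2)cc1` gives 77.9%, the highest of the three numbers, with both others beyond the scatter below it. The step of a number 1 percentage points higher from compound 1 to compound 2 (within the scatter) exchanged one group for another on a saturated ring carbon, whereas the step of a number 58 percentage points higher from compound 2 to compound 3 (beyond the scatter) exchanged a group on a carbonyl carbon. Compound 4 `CC(C)(C)C(=O)C1=C(O)C(=O)N(c2ccc(-c3ccon3)cc2)C1c1ccccc1OCCO` has not yet been measured. It differs from compound 3 by hydroxymethyl in place of hydrogen on a saturated chain carbon bound to an oxygen on an aromatic ring. Neither measured step touches that position or that kind of change, so none bears directly on it: the step from compound 2 to compound 3 stands alone as a large one, and the step from compound 1 to compound 2 lay within the scatter. Any figure for compound 4 must therefore be carried over from compound 3 with a wide margin. Compound 4 is expected to give about 50%, between 15% and 85%, in this assay. The step of a number 27.9 percentage points lower from compound 3 to compound 4 (beyond the scatter) is expected as a moderate move downward, though a step of no size beyond the scatter would not surprise.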

Compound 4, oral bioavailability: 49.9%
Compound 4: middle estimate off by 0.1 percentage points, on the high side; the measured number falls inside the stated range.
By their numbers in this assay, from the lowest: compounds 1 and 2 (each within the scatter of the next); then compound 4; then compound 3.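

In this assay, the saturated chain carbon bound to an oxygen on an aromatic ring proves not to be a neutral place for change: the step of a number 28 percentage points lower from compound 3 to compound 4 (beyond the scatter) comes from hydroxymethyl in place of hydrogen, which turns methoxy into 2-hydroxyethoxy. This is the first step shown at this position, and it is modest beside the large exchange on the carbonyl carbon. No measurement at hand explains the loss.

As far as these compounds go, it stays open whether the step belongs to the hydroxyl or to the longer chain itself: an ethoxy or 2-methoxyethoxy group here would separate the two, and a 2-aminoethoxy or carboxymethoxy group would try other end groups. From the compounds shown here alone, it also stays open whether the same change would give a similar step with 4-methoxyphenyl in place of tert-butyl on the carbonyl carbon.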